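The compounds below may be only part of what the source reports. "The series", "measured", "known", "first", "only" and "open" are said of these compounds alone.

Measured so far:
compound 1 `OCCCNc1nc(-c2ccccc2)nc2c1nnn2Cc1ccccc1F` — 3700000 nM
compound 2 `FC(F)(F)c1ccccc1Cn1nnc2c(NC3CCCCC3)nc(-c3ccccc3)nc21` — 6800000 nM
compound 3 `OCCNc1nc(-c2ccccc2)nc2c1nnn2Cc1ccccc1F` — 54000000 nM

Compound 3 stands at the top of these three numbers in an assay on isolated protein for binding affinity to adenosine receptor A1 (Bos taurus); on this read-out higher numbers stand for weaker inhibition and lower numbers for stronger inhibition: its nearest neighbour is compound 2, and compound 1 lies further off still, both gaps being beyond the scatter. Going by the values given here, the one step measured within this set, a 15-fold higher number from compound 1 to compound 3 (1.16 log units; beyond the scatter), shows that shortening the hydroxy chain on the ring nitrogen of compound 1 moves the number a long way upward.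

Compound 4 `Fc1ccccc1Cn1nnc2c(NC3CCCCC3)nc(-c3ccccc3)nc21` is the next compound in line. It differs from compound 3 by cyclohexyl in place of 2-hydroxyethyl on a nitrogen on an aromatic ring. Among the compounds with values here, no measured step covers exactly this exchange. The step from compound 1 to compound 3 bears on it only indirectly, as it shows how strongly this position responds to a change of the group. Compound 2, which carries the cyclohexylamino group with a different benzyl substituent, gives 6800000 nM, well below the number of compound 3. Since compound 2 already carries the group that enters here, compound 4 is expected to land near compound 2, with a sizeable downward step a 9.0-fold lower number from compound 3 to compound 4 (0.95 log units; beyond the scatter) from compound 3. The estimate for compound 4 is 6000000 nM, in a range from 1500000 nM to 25000000 nM.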

Compound 4, inhibition constant: 1150000 nM
Compound 4: middle estimate off by 5.2-fold (0.72 log units), on the high side, outside the stated range (below it).
By their numbers in this assay, from the lowest: compound 4; then compounds 1 and 2 (each within the scatter of the next); then compound 3.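

In this assay, going by these compounds alone, cyclohexyl on the nitrogen on an aromatic ring gives a 47-fold lower number from compound 3 to compound 4 (1.67 log units; beyond the scatter) and, set against the longer chain, a 3.2-fold lower number from compound 1 to compound 4 (0.51 log units; beyond the scatter), so the ring-bearing group sits lowest among the three groups tried with the rest of the molecule unchanged, where the earlier compounds had compared only two hydroxy chains at this place. The aromatic carbon that carries the fluoro group also counts, as fluoro in place of trifluoromethyl gives a 5.9-fold lower number from compound 2 to compound 4 (0.77 log units; beyond the scatter), so the number of the trifluoromethyl compound cannot stand in for that of the fluoro compound even with the same cyclohexylamino group present. Nothing available here accounts for any of these steps.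

The compounds shown leave open whether the lower number goes with the cyclohexyl ring itself or with the loss of the hydroxy group, a question that a plain propyl chain or a cyclopentyl group on the same nitrogen would help to settle. They also leave open how a chloro or methoxy group, or plain hydrogen, would compare with fluoro on that aromatic carbon.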